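A hydroxy group capped on compound 2

A few compounds are considered here, and "the series" means these few. Any claim that something is new, unique, unknown or untested is made for them only; others in the source may bear on it.

- Compound 1 `COc1cccc(/C=C/C(=O)c2ccc(OCC=C(C)C)cc2O)c1OC`: > 100000 nM (a limit)
- Compound 2 `COc1ccc(/C=C/C(=O)c2ccc(OCC=C(C)C)cc2O)c(OC)c1OC`: > 100000 nM (a limit)

In a functional assay on COLO 205 cells (Homo sapiens) for cytotoxicity, read by MTT assay, with a stated time of 24 h (a higher number here means a weaker inhibitor of growth, a lower number a stronger inhibitor of growth), compound 2 stands at > 100000 nM, which is a limit and not a number. Compound 3 `COc1ccc(/C=C/C(=O)c2ccc(OCC=C(C)C)cc2OCC=C(C)C)c(OC)c1OC` differs from it by 3-methylbut-2-en-1-yl in place of hydrogen on an oxygen on an aromatic ring, that is, hydroxy to (3-methylbut-2-en-1-yl)oxy. For the measured compounds named here, the only measured step is a step that the two limits leave unreadable from compound 1 to compound 2, and it concerns a different change, so it offers no size to carry over. What remains is the limit of > 100000 nM in this assay, at which 2 of the 2 values shown sit, so little gain in growth inhibition is expected. The expected move is a number no higher from compound 2 to compound 3 (the limit leaves the size open). For compound 3 the estimate in this assay is 100000 nM, with an expected range of 40000 nM to 250000 nM.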

Compound 3, concentration for 50% growth inhibition: > 100000 nM
Compound 3: no number, only a limit (the forecaster's own chance of this, stated with the estimate: 70%); the middle value sits exactly at the limit.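

For the compounds shown here, no step from compound 2 to compound 3 can be read, as both values are limits and not numbers: the limit of > 100000 nM in this assay, at which 3 of the 3 values shown sit. The compounds shown leave open which change to the shared core would give a readable number for growth inhibition.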